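A few compounds are considered here, and "the series" means these few. Any claim that something is new, unique, unknown or untested is made for them only; others in the source may bear on it.

Measured so far:
Compound 1, `COc1ccc(-c2cc(/C=C/C(=O)c3ccc(N)cc3)[nH]n2)cc1`, gives 23%.
Compound 2, `COc1cc(-c2cc(/C=C/C(=O)c3ccc(N)cc3)[nH]n2)cc(OC)c1OC`, gives -9%.

Both numbers come from a functional assay on SK-OV-3 cells (Homo sapiens) for cytotoxicity, read by sulforhodamine B assay, with a stated time of 48 h, tested at 10 uM; on this read-out higher numbers stand for a weaker effect at the one concentration tested and lower numbers for a stronger effect. On these two numbers compound 2 stands lowest; its nearest neighbour is compound 1, whose number is higher by a gap that lies beyond the scatter of this assay, so compound 2 shows the stronger effect of the two.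

Compound 3, `COc1cc(-c2cc(/C=C/C(=O)c3ccc(Cl)c(Cl)c3)[nH]n2)cc(OC)c1OC`, has not yet been measured in this assay. It differs from compound 2 in one place: 3,4-dichlorophenyl in place of 4-aminophenyl on a carbonyl carbon. Among the measured compounds shown here, the two measured compounds differ from each other elsewhere in the molecule, not on the carbonyl carbon, so no step between measured compounds shows what this exchange does. Without such a reference the expected step from compound 2 to compound 3 is a small one, a number 14 percentage points higher from compound 2 to compound 3 (beyond the scatter), with no direction that can be called beyond the scatter and a wide range around it. For compound 3 in this assay the estimate is 5%, expected between -25% and 40%.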

Compound 3, a percentage reported as activity, at one concentration (the size of the read-out at that concentration, not a potency): 26%
The estimate for compound 3 lay 21 percentage points below the measured number; the range from low to high includes it.
By their numbers in this assay, from the lowest: compound 2; then compounds 1 and 3 (each within the scatter of the next).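

In this assay, placing 3,4-dichlorophenyl in place of 4-aminophenyl on a carbonyl carbon gives a number 35 percentage points higher from compound 2 to compound 3 (beyond the scatter), so the effect at the one concentration tested is weaker with the new group. This is the only reading shown of a change at this place, since the earlier pair differed elsewhere in the molecule, and it shows that, with the rest of compound 2 held fixed, the group on this carbonyl carbon can move the read-out by more than the usual scatter. The exchange removes the amine and brings in chlorine, but no measurement shown accounts for the step or says which of these matters.

A plain phenyl or a 4-chlorophenyl on the same carbonyl carbon would help separate the loss of the amine from the arrival of the chlorine. Going by these compounds, whether the same exchange gives a step of similar size and direction on the core of compound 1 also stays open.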